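The compounds below may be only part of what the source reports. "The series", "measured", "known", "first", "only" and "open" are said of these compounds alone.

Three analogues of the shared core have been run in a functional assay on HCC78 cells (Homo sapiens) for antiproliferative activity, read by MTT assay, with a stated time of 48 h; on this read-out higher numbers stand for weaker inhibition and lower numbers for stronger inhibition. Compound 3 `Cc1ccc(CNC(=O)c2cccc(C(C)Oc3ccnc(Nc4cnn(C)c4)c3)c2)cc1` gives 8900 nM. Compound 1 `Cc1ccc(CNC(=O)c2cccc(C(C)Oc3ccnc(Nc4cnn(C5CCN(C)CC5)c4)c3)c2)cc1` gives 8100 nM, and compound 2 `CC(Oc1ccnc(Nc2cnn(C)c2)c1)c1cccc(C(=O)NCc2ccc(C#N)cc2)c1` gives 8700 nM. All three numbers sit within the scatter of one another, so compound 3 stands level with both: a 1.1-fold higher number from compound 1 to compound 3 (0.04 log units; within the scatter), and a 1.0-fold higher number from compound 2 to compound 3 (0.01 log units; within the scatter). Neither change at the edges of the molecule, on the aromatic nitrogen of the five-membered ring or on the benzylic aryl ring, has shifted the read-out.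

Compound 4 `Cc1ccc(CNC(=O)c2cccc(C(C)Oc3ccnc(Nc4cn(C)nc4C)c3)c2)cc1` is the next step from compound 3: methyl in place of hydrogen on an aromatic carbon. Going by the values given here, no measured step places a group on a carbon of this five-membered ring; the closest precedent is the change on its nitrogen from compound 1 to compound 3, which stayed within scatter. Without a closer precedent, no movement beyond scatter is expected for compound 4, and a 1.0-fold higher number from compound 3 to compound 4 (0.00 log units; within the scatter) is the estimated step. In this assay compound 4 is therefore expected at about 9000 nM, with a range from 4500 nM to 18000 nM.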

Compound 4, half-maximal inhibitory concentration: 17500 nM
Compound 4: the middle estimate sits 1.9-fold (0.29 log units) below what was measured; measured number inside the range.
By their numbers in this assay, from the lowest: compounds 1, 2, 3 and 4 (each within the scatter of the next, the first and the last beyond it).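

Methyl on this aromatic carbon of the five-membered ring, next to the ring atom that bears a large group, gives a 2.0-fold higher number from compound 3 to compound 4 (0.29 log units; within the scatter) in this assay, so a first substitution at this carbon does not move the read-out beyond the scatter. The 1,3-dimethyl-1H-pyrazol-4-yl group in place of 1-(1-methylpiperidin-4-yl)-1H-pyrazol-4-yl gives a 2.2-fold higher number from compound 1 to compound 4 (0.33 log units; beyond the scatter) and is the first listed step to pass the scatter, though only modestly, whereas methyl alone in place of 1-methylpiperidin-4-yl on the ring nitrogen stayed within it. No measurement at hand explains this result.

From the compounds shown here alone, whether a longer chain such as ethyl, or an amine or a halogen such as chlorine, on this same carbon would behave like methyl remains open. Also open, going by these compounds, is how methyl on this carbon reads with 1-methylpiperidin-4-yl kept on the ring nitrogen.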